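Sulfonamide replacement of the cinnamide in a D3 series

The compounds below may be only part of what the source reports. "The series", "measured", "known", "first", "only" and "open" are said of these compounds alone.

Measured compounds in an assay on brain for displacement of a labelled ligand from D(3) dopamine receptor (Rattus norvegicus); on this read-out higher numbers stand for weaker inhibition and lower numbers for stronger inhibition:
compound 1, `CCCN(CC[C@H]1CC[C@H](NC(=O)/C=C/c2cccc(F)c2)CC1)[C@H]1CCc2nc(N)sc2C1`, 9.9 nM
compound 2, `CCCN(CC[C@H]1CC[C@H](NC(=O)c2ccccc2-n2cccn2)CC1)[C@H]1CCc2nc(N)sc2C1`, 2 nM
compound 3, `CCCN(CC[C@H]1CC[C@H](NC(=O)c2ccc(-n3cccn3)cc2)CC1)[C@H]1CCc2nc(N)sc2C1`, 3 nM

Compound 1 gives the highest number of the three in this assay . Its nearest neighbour is compound 3, by a 3.3-fold lower number from compound 1 to compound 3 (0.52 log units; beyond the scatter), and its furthest is compound 2, by a 1.5-fold higher number from compound 2 to compound 3 (0.18 log units; within the scatter) being within the scatter, so compounds 2 and 3 cannot be ordered against each other; the step of a 5.0-fold lower number from compound 1 to compound 2 (0.69 log units; beyond the scatter) is the larger of the two departures from compound 1.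

Compound 4, `CCCN(CC[C@H]1CC[C@H](NS(=O)(=O)c2ccc(Cl)nc2)CC1)[C@H]1CCc2nc(N)sc2C1`, is not yet measured. It differs from compound 1 in one place: (6-chloropyridin-3-yl)sulfonyl in place of (2-(3-fluorophenyl)ethenyl)carbonyl on an amine nitrogen. Both measured steps, a 5.0-fold lower number from compound 1 to compound 2 (0.69 log units; beyond the scatter) and a 3.3-fold lower number from compound 1 to compound 3 (0.52 log units; beyond the scatter), replace the same (2-(3-fluorophenyl)ethenyl)carbonyl group with an aromatic carbonyl, and both gave modest lower numbers. Among the measured compounds shown here, neither replaces the carbonyl itself with a sulfonyl, so no measured step bears directly on compound 4. A step in either direction is possible; with nothing to weight it, no step beyond the scatter is expected, a 1.0-fold higher number from compound 1 to compound 4 (0.00 log units; within the scatter), and compound 4 is estimated at 10 nM, between 2.5 nM and 40 nM.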

Compound 4, inhibition constant: 0.63 nM
The estimate for compound 4 lay 16-fold (1.20 log units) above the measured number; the whole stated range lies above it.
By their numbers in this assay, from the lowest: compound 4; then compounds 2 and 3 (each within the scatter of the next); then compound 1.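

In this assay, moving from the carbonyl to a sulfonyl on this amine nitrogen, with (6-chloropyridin-3-yl)sulfonyl in place of (2-(3-fluorophenyl)ethenyl)carbonyl, gives a 16-fold lower number from compound 1 to compound 4 (1.20 log units; beyond the scatter) and is a large step, whereas the two aromatic carbonyl replacements gave modest ones. Among the compounds shown here, the amide carbonyl shared by compounds 1, 2 and 3 is therefore not required for a low number at this position, which the earlier compounds, all keeping that carbonyl, could not show. Nothing available explains the size of this step.

Because the linking group and the aromatic ring change together, the compounds shown do not separate the share of the sulfonyl from that of the 6-chloropyridin-3-yl ring. Also open, going by these compounds, is what the chlorine contributes, which a methoxy group or an amine at the same place on the ring would test.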